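The compounds below may be only part of what the source reports. "The series", "measured", "known", "first", "only" and "open" are said of these compounds alone.

Measured compounds:
- compound 1, `CC(C)CCn1ccc(-c2ccc(Oc3ccccc3)cc2)c(C#N)c1=O`: 42 nM
- compound 2, `CC(C)CCn1ccc(-c2ccc(Oc3ccncc3)cc2)c(C#N)c1=O`: 550 nM
- compound 3, `CNc1ccc(-c2ccn(CCC(C)C)c(=O)c2C#N)cc1`: 460 nM

These three share one core and differ only in the group carried on the outer benzene ring. In a functional assay on CHO cells for positive allosteric modulation of metabotropic glutamate receptor 2 (Homo sapiens), read by scintillation counting and GTPgammaS binding, with a stated time of 30 min (on this read-out lower numbers stand for an effect already at smaller amounts and higher numbers for an effect only at larger amounts of compound), compound 3 stands second highest of the three numbers; its nearest neighbour is compound 2, a 1.2-fold lower number from compound 2 to compound 3 (0.08 log units; within the scatter), while compound 1 lies far off, an 11-fold higher number from compound 1 to compound 3 (1.04 log units; beyond the scatter).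

Compound 4, `Cc1ncccc1Oc1ccc(-c2ccn(CCC(C)C)c(=O)c2C#N)cc1`, has not been measured. It differs from compound 3 by (2-methylpyridin-3-yl)oxy in place of methylamino on an aromatic carbon. Among the measured compounds shown here, two measured steps bear on this. Reading the step from compound 1 to compound 3 backwards, replacing methylamino by an aryl ether brought a much lower number; but the step from phenyl ether to pyridyl ether, a 13-fold higher number from compound 1 to compound 2 (1.12 log units; beyond the scatter), shows that a pyridine in that ether can take most of that gain away again. The ether entering compound 4 is a pyridine too, though with a methyl and a different nitrogen placement, so in this assay a moderate step downward is expected, a 3.1-fold lower number from compound 3 to compound 4 (0.49 log units; beyond the scatter), landing between compound 1 and compound 2. Compound 4 is therefore estimated at 150 nM, with a likely range from 40 nM to 600 nM.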

Compound 4, half-maximal effective concentration: 275 nM
The estimate for compound 4 lay 1.8-fold (0.26 log units) below the measured number; the range from low to high includes it.
By their numbers in this assay, from the lowest: compound 1; then compounds 4, 3 and 2 (each within the scatter of the next).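

In this assay, a second pyridine ether, with a methyl and a different nitrogen placement, sits level with both the small methylamino compound (a 1.7-fold lower number from compound 3 to compound 4 (0.22 log units; within the scatter)) and the pyridin-4-yl ether (a 2.0-fold lower number from compound 2 to compound 4 (0.30 log units; within the scatter)). The gap to the plain phenyl ether remains (a 6.5-fold higher number from compound 1 to compound 4 (0.82 log units; beyond the scatter)), so on this aromatic carbon, para to a large group, both pyridine ethers stand clearly apart from compound 1, and an aryl ether in itself, though much larger than methylamino, does not bring the number of compound 1. No measurement here gives a reason for this difference between the phenyl and pyridine rings.

What the compounds shown leave open is how much of the gap between compound 1 and compound 4 belongs to the ring nitrogen and how much to the methyl, which a 2-methylphenyl ether or an unmethylated pyridin-3-yl ether would help to separate. Also open, on these data alone, is whether the oxygen link itself matters, a question that an anilino group in place of the phenoxy of compound 1 could address.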